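The source may report more compounds than this note shows. Statements on the series, on what has been measured and on what is new or still open speak of the compounds shown alone.

Working notes on the series in a functional assay on HL-60 cells (Homo sapiens) for cytotoxicity, read by WST assay, with a stated time of 48 h; a lower number here means a stronger inhibitor, a higher number a weaker inhibitor. Compound 1 `COc1cc(C(c2ccc(O)c(OC)c2)[C@@H](C)[C@@H](C)CO)ccc1O` gives > 100000 nM, which is a limit of the assay and not a number. Compound 2 `COc1cc(C(c2ccc(O)c(OC)c2)[C@H](CF)C(C)C)ccc1O` reads 19000 nM. Compound 3 `COc1cc(C(c2ccc(O)c(OC)c2)[C@H](C)[C@H](C)CF)ccc1O` reads 56000 nM, the higher of the two actual numbers, and compound 2 is its nearest neighbour.

Compound 4 `COC[C@@H](C)[C@H](C)C(c1ccc(O)c(OC)c1)c1ccc(O)c(OC)c1` differs from compound 3 as follows: 2-(methoxymethyl)-1-methylpropyl in place of 2-(fluoromethyl)-1-methylpropyl on a saturated chain carbon bound to two aromatic carbons. This places 2-(methoxymethyl)-1-methylpropyl in place of 2-(fluoromethyl)-1-methylpropyl on a saturated chain carbon bound to two aromatic carbons.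

Going by the values given here, no measured step makes this exchange. The nearest one replaces 2-(hydroxymethyl)-1-methylpropyl with the same fluorinated chain: an at least 1.7-fold lower number from compound 1 to compound 3 (0.25 log units; that floor lies within the scatter), a floor within the scatter. The other two steps, an at least 5.2-fold lower number from compound 1 to compound 2 (0.72 log units; beyond the scatter) and a 2.9-fold higher number from compound 2 to compound 3 (0.47 log units; beyond the scatter), involve the differently arranged chain of compound 2 and bear only on the likely size of a change.

With compound 3 at 56000 nM as the anchor, no step beyond the scatter is expected in this assay. The expected step is a 1.1-fold higher number from compound 3 to compound 4 (0.03 log units; within the scatter). For compound 4 the estimated value is 60000 nM, with an expected range of 28000 nM to 120000 nM.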

Compound 4, half-maximal inhibitory concentration: 73000 nM
For compound 4 the middle estimate is 1.2-fold (0.09 log units) below the measured one; the measured number falls inside the stated range.
By their numbers in this assay, from the lowest: compound 2; then compounds 3 and 4 (each within the scatter of the next). At a limit, above all of these: compound 1.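

At the saturated chain carbon bound to two aromatic carbons, this assay does not separate 2-(methoxymethyl)-1-methylpropyl from 2-(fluoromethyl)-1-methylpropyl: the exchange gives a 1.3-fold higher number from compound 3 to compound 4 (0.12 log units; within the scatter). The differently arranged chain stays clear of this one too, with a 3.8-fold higher number from compound 2 to compound 4 (0.58 log units; beyond the scatter), so its lower number now stands beyond the scatter against both of the other chains that carry a defined value. The step of an at least 1.3-fold lower number from compound 1 to compound 4 (0.13 log units; that floor lies within the scatter) offers only a floor, and compound 1 sits at a limit of the assay, not a number: the limit of > 100000 nM in this assay, at which 1 of the 4 values shown sits.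

As far as these compounds go, whether an amine or a carboxylic acid at the chain end, or a longer chain, would move the number remains open. Also open, from the compounds shown here alone, is whether a methoxy or hydroxy group on the arrangement of compound 2 would hold the lower number seen with fluorine there.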